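Swapping chloro for methyl on a sulfonylurea aorta relaxant

A few compounds are considered here, and "the series" means these few. Any claim that something is new, unique, unknown or untested is made for them only; others in the source may bear on it.

Of the compounds shown here, three built around an aryl sulfonylurea have been tested in a functional assay on thoracic aorta (Rattus norvegicus, strain Wistar), with a stated time of 15 min; on this read-out lower numbers stand for an effect already at smaller amounts and higher numbers for an effect only at larger amounts of compound. Compound 1, with the structure `CCOc1ccc(F)cc1C(C)NC(=O)N(C)S(=O)(=O)c1ccc(C)cc1`, gives 7800 nM in this assay. Compound 2, with the structure `CCOc1ccc(F)cc1C(C)NC(=O)N(C)S(=O)(=O)c1ccc(Cl)cc1`, gives 24500 nM. These two differ in only one place, (methyl in place of chloro on an aromatic carbon), and the change made a step of a 3.1-fold lower number from compound 2 to compound 1 (0.50 log units; beyond the scatter), a modest gain that still lies beyond the usual scatter.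

Compound 3, with the structure `CC(NC(=O)NS(=O)(=O)c1ccc(Cl)cc1)c1ccccc1OCc1ccccc1`, gives 157000 nM, the highest of the three numbers; it sits well apart from compound 2 and further still from compound 1. How the core of compound 3 differs from that of compound 2 is not broken down here, since the two differ in more than one place.

Compound 4, with the structure `Cc1ccc(S(=O)(=O)NC(=O)NC(C)c2ccccc2OCc2ccccc2)cc1`, has not yet been measured. It differs from compound 3 by methyl in place of chloro on an aromatic carbon, and the place around the change reads the same as in the earlier pair, so this is the same change applied to a different core. The step from compound 3 to compound 4 is expected to be a 2.9-fold lower number from compound 3 to compound 4 (0.46 log units; beyond the scatter), because the same exchange on the neighbouring core gave a 3.1-fold lower number from compound 2 to compound 1 (0.50 log units; beyond the scatter), though the different core adds uncertainty. Compound 4 is therefore estimated at about 55000 nM, most likely somewhere between 20000 nM and 160000 nM.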

Compound 4, half-maximal effective concentration: > 200000 nM
Compound 4: a limit, no number (the forecaster's own chance of this, stated with the estimate: 15%); middle value at least 3.6-fold (0.56 log units) away from the limit.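

In this assay compound 4 gives > 200000 nM, which is a limit of the assay and not a number. The new step reads an at least 1.2-fold higher number from compound 3 to compound 4 (0.10 log units; that floor lies within the scatter), so methyl in place of chloro did not bring the same result on the second core as on the first, and a change that helped on one core cannot simply be assumed to help on a close relative: the same change on two cores in this assay, a 3.1-fold lower number (0.50 log units; beyond the scatter) from compound 2 to compound 1 and an at least 1.2-fold higher number (0.10 log units; that floor lies within the scatter) from compound 3 to compound 4, at least 4.0-fold (0.60 log units) apart, beyond the scatter of two such steps This does not show how large the new step really is, or whether compound 4 truly lies beyond the scatter from compound 3, as the floor of the step is all that can be read and the real number may lie anywhere past the end of the range: the limit of > 200000 nM in this assay, at which 1 of the 4 values shown sits.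

The two cores differ from each other in more than one place, so the compounds shown leave open which of those places decides how the exchange turns out. They also leave open how other groups at this same place on the aromatic ring, such as a methoxy group or an amine, would behave on each of the two cores.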